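A trifluorinated hydroxy chain on the shared core

This account rests on a few compounds, and the source may have more. Where it says the series, first, only, none or still open, it means among the compounds named here.

In a physicochemical assay for solubility, at pH 6.8 (on this read-out lower numbers stand for lower solubility and higher numbers for higher solubility), compound 2 (`CC(O)CNC(=O)c1nc(Br)c(C(F)(F)F)cc1N`) stands highest of the two measured at 120 ug/mL against compound 1 (`COC(=O)c1nc(-c2ccco2)c(C(F)(F)F)cc1N`) at 11 ug/mL with a gap beyond the scatter. Compound 3 (`Nc1cc(C(F)(F)F)c(Br)nc1C(=O)NC[C@@H](O)C(F)(F)F`) carries 2,2,2-trifluoro-1-hydroxyethyl in place of 1-hydroxyethyl on a saturated chain carbon bound to an amide-type nitrogen. Among the measured compounds shown here, no measured pair shows this change, so the expectation rests on the structure alone. A moderate fall in this assay is expected (a 2.7-fold lower number from compound 2 to compound 3 (0.43 log units; beyond the scatter)) and may only just clear the scatter. The estimate for compound 3 is 45 ug/mL with an expected range of 15 ug/mL to 130 ug/mL as the likely span.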

Compound 3, solubility: 177 ug/mL
Estimate against measurement, compound 3: 3.9-fold (0.59 log units) below, and the stated range ends below it.
By their numbers in this assay, from the lowest: compound 1; then compounds 2 and 3 (each within the scatter of the next).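

In this assay, 2,2,2-trifluoro-1-hydroxyethyl in place of 1-hydroxyethyl on a saturated chain carbon bound to an amide-type nitrogen gives a 1.5-fold higher number from compound 2 to compound 3 (0.17 log units; within the scatter). Among the compounds shown here, this position therefore accepts the trifluorinated chain without a shift beyond the scatter, the first reading of a change at this place. Nothing measured on these compounds gives a reason for this result.

Still open, on these data alone, is how this read-out responds if an amine or a carboxylic acid replaces the hydroxy group, or with a longer chain. As far as these compounds go, the opposite configuration of the defined stereocentre also remains open.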